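This account rests on a few compounds, and the source may have more. Where it says the series, first, only, none or still open, it means among the compounds named here.

Measured so far:
compound 1, `C/N=C(\S)NCCCCn1nc(-c2ccccc2)ccc1=O`: 87.1%
compound 2, `CC/N=C(\S)NCCCCn1nc(-c2ccccc2)ccc1=O`: 67.7%

In a functional assay on the whole organism with Rattus norvegicus as the target, at a dose of 100 mg/kg (on this read-out higher numbers stand for more inhibition at the one dose given (going by the name of the read-out) and lower numbers for less inhibition), compound 1 gives 87.1% and compound 2 gives 67.7%. Among the measured compounds shown here, compound 2 thus stands lowest of the two numbers recorded, and the one step between them, a number 19.4 percentage points lower from compound 1 to compound 2 (beyond the scatter), lies beyond the scatter.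

Compound 3, `C/N=C(\NC#N)NCCCCn1nc(-c2ccccc2)ccc1=O`, has not yet been tested. It differs from compound 2 as follows: a group of 6 heavy atoms (3 carbon, 3 nitrogen; no ring) in place of a group of 5 heavy atoms (3 carbon, 1 nitrogen, 1 sulfur; no ring), on an amine nitrogen. The group that enters carries a methyl on the double-bonded nitrogen, as compound 1 does, while the thiocarbonyl sulfur gives way to a cyanamide nitrogen.

For the measured compounds named here, only one measured step exists, a number 19.4 percentage points lower from compound 1 to compound 2 (beyond the scatter), and it concerns a methyl in place of hydrogen on a saturated chain carbon, not the exchange of sulfur for nitrogen made here. It therefore bears on the present change only in part. Since compound 1 with its methyl on the double-bonded nitrogen gave 87.1%, compound 3 is expected to sit between compound 2 and compound 1, with a step of a number 7.3 percentage points higher from compound 2 to compound 3 (within the scatter) in this assay. The estimate for compound 3 is 75%, within 50% to 92%.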

Compound 3, a percentage reported as inhibition, in the whole organism at one dose (the size of the read-out at that dose, not a potency): 79%
For compound 3 the middle estimate is 4 percentage points below the measured one, within the range that was stated.
By their numbers in this assay, from the lowest: compound 2; then compounds 3 and 1 (each within the scatter of the next).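

In this assay, cyanoamino in place of sulfanyl on the carbon with a double bond to nitrogen gives a number 8.1 percentage points lower from compound 1 to compound 3 (within the scatter), so at this dose the sulfur is not needed for a read-out on the level of compound 1. The exchange on the amine nitrogen gives a number 11.3 percentage points higher from compound 2 to compound 3 (beyond the scatter), and this step also carries a methyl on the double-bonded nitrogen where compound 2 has an ethyl group. Set beside a number 19.4 percentage points lower from compound 1 to compound 2 (beyond the scatter), it suggests that among these three compounds the group on the double-bonded nitrogen accounts for the steps beyond the scatter, while the sulfanyl and cyanoamino exchange does not, though no measurement at hand gives a reason for either result.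

The compounds shown leave open how cyanoamino would read with an ethyl group on the double-bonded nitrogen, and whether a carbonyl oxygen in place of that carbon's sulfanyl or cyanoamino group would hold the read-out. They also leave open whether a propyl group on that nitrogen would extend the step seen with ethyl, and how these compounds would compare across a range of doses rather than at a single one.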